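The source may report more compounds than this note shows. Statements on the series, on what has been measured and on what is new or still open speak of the compounds shown alone.

Compound 1 `C#CCN(CCC1CCN(Cc2ccccc2)CC1)Cc1ccc2cccc(O)c2n1` gives 35600 nM in an assay on isolated protein for inhibition of Amine oxidase [flavin-containing] A (Homo sapiens), read by fluorescence and Amplex Red, with stated times of 30 min and 1 h; on this read-out lower numbers stand for stronger inhibition and higher numbers for weaker inhibition.
Compound 2 `C#CCN(CCCC1CCN(Cc2ccccc2)CC1)Cc1ccc2cccc(O)c2n1` gives 37000 nM in this assay.

Both values were read in this assay, and compound 1 has the lower of the two numbers, though its value and that of compound 2 lie within the scatter of each other, so nothing separates them. Compound 3 `C#CCN(Cc1ccc2cccc(O)c2n1)C(C#N)CC1CCN(Cc2ccccc2)CC1` shares the core of compound 1 and differs from it in one place: cyano in place of hydrogen on a saturated chain carbon bound to an amine nitrogen and a saturated chain carbon. Among the compounds with values here, no step between two measured compounds bears on this change, since compound 1 and compound 2 differ only in chain length. Within the data shown here, with no measured step to lean on, the expectation for compound 3 is that the step of a 1.2-fold lower number from compound 1 to compound 3 (0.07 log units; within the scatter) stays small, in either direction, and most likely within the usual scatter. Compound 3 is therefore estimated at 30000 nM in this assay, with a range from 8000 nM to 120000 nM.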

Compound 3, half-maximal inhibitory concentration: 12200 nM
Beside the measured number, compound 3's estimate is 2.5-fold (0.39 log units) above it, within the range that was stated.
By their numbers in this assay, from the lowest: compound 3; then compounds 1 and 2 (each within the scatter of the next).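

In this assay, cyano in place of hydrogen on a saturated chain carbon bound to an amine nitrogen and a saturated chain carbon gives a 2.9-fold lower number from compound 1 to compound 3 (0.47 log units; beyond the scatter), a modest step but one beyond the scatter. This is the first change shown to move the number measurably, since the values of compound 1 and compound 2, which differ only in chain length, lie within the scatter of each other. It shows that this chain carbon accepts a substituent and that the read-out responds to this one, although nothing given here accounts for the step.

On these data alone, whether a methyl group or a carboxylic acid on this carbon would move the number in the same direction remains open. So does whether cyano would produce a similar step on the longer chain of compound 2.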